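This account rests on a few compounds, and the source may have more. Where it says the series, first, only, none or still open, it means among the compounds named here.

Measured compounds:
- compound 1 `CCC1CCCCN1C(=O)n1cc(-c2ccc(-c3ccccc3)cc2)nn1` gives 20 nM
- compound 2 `O=C(N1C[C@@H](O)C=C[C@@H]1Cc1ccccc1)n1ncc(C(O)(c2ccc(F)cc2)c2ccc(F)cc2)n1` gives 20 nM

In an assay on HEK-293T cells for inhibition of diacylglycerol lipase-alpha (Homo sapiens), read by colorimetric assay (a higher number here means a weaker inhibitor, a lower number a stronger inhibitor), compound 1 gives 20 nM. In this assay compound 2 gives 20 nM. At the digits shown compound 2 stands level with compound 1, its nearest neighbour among the measured compounds, and the gap between the two lies within the scatter, so no order between them can be read. For the measured compounds named here, compound 1 and compound 2 share no single-point relation, so no measured step is available.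

Compound 3 `O=C(N1C[C@H](O)C=C[C@@H]1Cc1ccccc1)n1ncc(C(O)(c2ccc(F)cc2)c2ccc(F)cc2)n1` is the next compound to be measured in this assay. Its relation to compound 2 is the two compounds have the same atoms and bonds and differ only in configuration as drawn: 1 of 2 stereo elements differ; a stereocentre at a saturated ring carbon is drawn S in compound 2 and R in compound 3. Nothing measured here shows what an inversion of a single ring stereocentre does in this assay, and the two drawn configurations cannot be ranked from the data. An inverted stereocentre at the hydroxyl-bearing ring carbon is expected to cost some potency, a step of a 2.5-fold higher number from compound 2 to compound 3 (0.40 log units; beyond the scatter) beyond the scatter but of uncertain size in either direction. Compound 3 is therefore estimated at 50 nM in this assay, within a wide range from 10 nM to 400 nM.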

Compound 3, half-maximal inhibitory concentration: 12.6 nM
For compound 3 the middle estimate is 4.0-fold (0.60 log units) above the measured one, and the stated range covers the measured number.
By their numbers in this assay, from the lowest: compounds 3, 1 and 2 (each within the scatter of the next).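

In this assay, the inversion of the stereocentre at a saturated ring carbon now has a measured size: a 1.6-fold lower number from compound 2 to compound 3 (0.20 log units; within the scatter). No order can be read between the two drawn configurations, so in this pair, S or R at this carbon makes no difference that stands clear of the usual scatter, something compound 1 and compound 2 could not show, as they share no single-point relation. The comparison is a clean one, with no change of atoms or bonds to weigh against the inversion: the fact that compounds 2 and 3 differ only in the configuration as drawn

On these data alone, what the second stereocentre, drawn alike in compound 2 and compound 3, contributes in this assay stays open, and this one pair says nothing about whether the same insensitivity would hold on a different core such as that of compound 1. Also open, as far as these compounds go, is whether the hydroxyl group itself matters at this carbon, for instance whether a methoxy group or an amine in its place would leave the number within the scatter of these two compounds, as the inversion does.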